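The source may report more compounds than this note shows. Statements on the series, on what has been measured and on what is new or still open speak of the compounds shown alone.

Series notes. Compound 1 `Cc1c(OCCCCOc2ccc(C(=O)O)cc2)ccc(C(=O)CC2CCCC2)c1O` and compound 3 `Cc1c(OCCCCOc2cccc(C(=O)O)c2)ccc(C(=O)CC2CCCC2)c1O` share one core; compound 2 `Cc1c(OCCCCOc2ccc(C(=O)O)cc2)ccc(C(=O)CC(C)C)c1C` and compound 4 `Cc1c(OCCCCOc2cccc(C(=O)O)c2)ccc(C(=O)CC(C)C)c1C` share another, and the difference between the two cores is not broken down here. In an assay on HEK293 cells for positive allosteric modulation of metabotropic glutamate receptor 3 (Rattus norvegicus), read by thallium flux, with a stated time of 2.5 min (a higher number here means a larger maximal response, a lower number a smaller maximal response), compound 1 gives 26.7% and compound 3 gives 92.9%; the change between them is 3-carboxyphenyl in place of 4-carboxyphenyl on an oxygen on a saturated carbon and the step is a number 66.2 percentage points higher from compound 1 to compound 3 (beyond the scatter). In this assay compound 2 gives 16.6%, the lowest of the three measured numbers, with compound 1 beyond the scatter above it and compound 3 much further beyond. Compound 4 has not yet been measured in this assay. It differs from compound 2 by 3-carboxyphenyl in place of 4-carboxyphenyl on an oxygen on a saturated carbon, the same change as that from compound 1 to compound 3, made at the same place. Because a number 66.2 percentage points higher from compound 1 to compound 3 (beyond the scatter) was large on the first core, a step in the same direction is expected on the second core, but its size cannot be taken as settled from a single earlier pair: the second core is a different one, and compound 2 starts from a lower number than compound 1. For compound 4 the expected step is a number 48.4 percentage points higher from compound 2 to compound 4 (beyond the scatter), somewhat smaller than the earlier one. For compound 4 in this assay the estimate is 65%, between 30% and 95%.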

Compound 4, largest response reached (reported as percent of maximum), in percent of the reference or control that the assay uses: 18.3%
The estimate for compound 4 lay 46.7 percentage points above the measured number, and the stated range ends above it.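

In this assay, exchanging 4-carboxyphenyl for 3-carboxyphenyl on the second core gives a number 1.7 percentage points higher from compound 2 to compound 4 (within the scatter), so the large rise seen on the core of compound 1 does not reappear there. The change therefore does not carry over in size from one core to the other: the same change on two cores in this assay, a number 66.2 percentage points higher (beyond the scatter) from compound 1 to compound 3 and a number 1.7 percentage points higher (within the scatter) from compound 2 to compound 4, 64.5 percentage points apart, beyond the scatter of two such steps This shows that the result of this exchange on one core cannot be used as a reliable guide to its result on the other, but two pairs do not show which structural difference between the cores accounts for the gap, nor how the change would behave on any further core.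

As far as these compounds go, it remains open whether the hydroxyl on the aromatic ring of compound 1 or the cyclopentyl group in its ketone side chain is what allows the 3-carboxyphenyl compound to reach the high response, since compound 2 and compound 4 differ from that core in both features at once. Also open, from the compounds shown here alone, is whether a tetrazole in place of the carboxylic acid, or a longer chain in place of the four-carbon link to the oxygen, would keep the response of compound 3 or alter the dependence on the core.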